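This account rests on a few compounds, and the source may have more. Where it says the series, first, only, none or still open, it means among the compounds named here.

In a functional assay on HCT-116 cells (Homo sapiens) for inhibition, read by MTT assay, with a stated time of 48 h (on this read-out higher numbers stand for weaker inhibition and lower numbers for stronger inhibition), compound 1 `COc1ccc(-n2c(S)nnc2-c2cc(OC)c(OC)c(OC)c2)cc1`, with hydrogen on the sulfur, gives > 60000 nM, which is a limit. Compound 2 `COc1ccc(CSc2nnc(-c3cc(OC)c(OC)c(OC)c3)n2-c2ccc(OC)cc2)cc1` gives 49600 nM. Compound 3 `COc1ccc(-n2c(SCC(=O)c3ccc(F)cc3)nnc2-c2cc(OC)c(OC)c(OC)c2)cc1` gives > 60000 nM, again a limit and not a number, so it stands at the limit of > 60000 nM in this assay, at which 2 of the 3 values shown sit. Compound 4 `CCOC(=O)CSc1nnc(-c2cc(OC)c(OC)c(OC)c2)n1-c1ccc(OC)cc1` carries ethoxy in place of 4-fluorophenyl on a carbonyl carbon. Within the data shown here, no measured step makes this exchange. The nearest are the changes on the sulfur: an at least 1.2-fold lower number from compound 1 to compound 2 (0.08 log units; that floor lies within the scatter), an at least 1.2-fold higher number from compound 2 to compound 3 (0.08 log units; that floor lies within the scatter) and a step that the two limits leave unreadable from compound 1 to compound 3. The first two have floors within the scatter, and the third has no readable size. Among the measured compounds shown here, compound 2, at 49600 nM, holds the only actual number, so no step beyond the scatter is expected in this assay, in either direction. The expected step is an at least 1.0-fold lower number from compound 3 to compound 4 (0.03 log units; that floor lies within the scatter), and another limit would be no surprise. The estimate for compound 4 is 55000 nM, with an expected range from 30000 nM to 100000 nM.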

Compound 4, half-maximal inhibitory concentration: > 60000 nM
Compound 4 was reported as a limit (the forecaster's own chance of this, stated with the estimate: 60%); middle value at least 1.0-fold (0.03 log units) away from the limit.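

In this assay compound 4 gives > 60000 nM, which is a limit, so with ethoxy as with 4-fluorophenyl on this carbonyl carbon no actual number appears. Among these compounds, the one readable step is an at least 1.2-fold higher number from compound 2 to compound 4 (0.08 log units; that floor lies within the scatter), for ethoxycarbonyl in place of 4-methoxyphenyl on a saturated chain carbon bound to a sulfur. The steps to compound 4 from compound 3 and from compound 1 cannot be read, since both ends of each are limits, and the series now stands as follows: the limit of > 60000 nM in this assay, at which 3 of the 4 values shown sit.

From the compounds shown here alone, how far compound 4 lies past its limit stays open, so nothing ranks it against compound 3. Also open, going by these compounds, is whether a carboxylic acid or an amide on this carbonyl carbon, or a longer chain on the sulfur, would give an actual number.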